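Replacing 1-benzofuran-2-yl with methoxy in a cytotoxicity test

This account rests on a few compounds, and the source may have more. Where it says the series, first, only, none or still open, it means among the compounds named here.

- compound 1 `COC(=O)c1ccc(NCc2cncn2Cc2ccc(-c3ccccc3)cc2)cc1-c1ccccc1`: > 1000 nM (a limit)
- compound 2 `c1ccc(-c2ccc(Cn3cncc3CNc3ccc(-c4cc5ccccc5o4)c(-c4ccccc4)c3)cc2)cc1`: > 10000 nM (a limit)

In a toxicity assay on NIH3T3 cells (Mus musculus) for cytotoxicity, read by resazurin assay (a lower number here means that less compound is needed, a higher number that more compound is needed for the effect), compound 2 gives > 10000 nM, which is a limit and not a number. Compound 3 `COc1ccc(NCc2cncn2Cc2ccc(-c3ccccc3)cc2)cc1-c1ccccc1` carries methoxy in place of 1-benzofuran-2-yl on an aromatic carbon, ortho to a phenyl group and para to a large group: methoxy in place of 1-benzofuran-2-yl on an aromatic carbon. Within the data shown here, the one measured step that bears on this position, a step that the two limits leave unreadable from compound 1 to compound 2, has no readable size, so it shows no direction. No step beyond the scatter is therefore expected in this assay. The expected step is a number no higher from compound 2 to compound 3 (the limit leaves the size open). For compound 3 the estimate is 10000 nM, with an expected range from 2500 nM to 40000 nM.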

Compound 3, half-maximal effective concentration: > 1000 nM
Compound 3: only a limit was reported; the forecaster's own chance of this, stated with the estimate: 55%; the middle value is on the limit's open side.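

Among these compounds, compound 1, compound 2 and compound 3 are each reported only as a limit in this assay, so no step between them can be read. On these data alone, how much of each compound produces the effect remains open.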